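The source may hold more compounds than are shown below. What is called first, only, known or untested is meant among the compounds shown, and "the series" means these compounds.

Of the compounds shown here, two have been measured in a functional assay on A549 cells (Homo sapiens) for inhibition, read by sulforhodamine B assay, with a stated time of 74 h; a higher number here means a weaker inhibitor, a lower number a stronger inhibitor. Compound 1 `COc1ccc(S(=O)(=O)N2C(=O)COC23C=CC(=O)C=C3)cc1` reads > 10000 nM, which is a limit of the assay and not a number. Going by the values given here, compound 2 `O=C1C=CC2(C=C1)OCC(=O)N2S(=O)(=O)c1ccc(OC(F)(F)F)cc1` gives 40 nM, the only actual number so far.

The next compound, compound 3 `O=C1C=CC2(C=C1)OCC(=O)N2S(=O)(=O)c1ccc(C(F)(F)F)cc1`, alters the same group on the aromatic ring: trifluoromethyl in place of trifluoromethoxy on an aromatic carbon. In words, trifluoromethyl stands in place of trifluoromethoxy on an aromatic carbon, para to a large group, while the rest of the molecule stays the same.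

Among the compounds with values here, only one measured step bears on this change, and it is a large one: an at least 250-fold lower number from compound 1 to compound 2 (2.39 log units; beyond the scatter). That step was a different swap, in which trifluoromethyl replaced methyl on an oxygen. Compound 3 keeps the trifluoromethyl and loses only the oxygen. A change of that size is therefore not expected in this assay, only a small move towards a higher number, meaning a slightly weaker inhibitor.

The expected change is a 1.8-fold higher number from compound 2 to compound 3 (0.24 log units; within the scatter). For compound 3 the estimated value is 70 nM, with an expected range from 20 nM to 350 nM.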

Compound 3, half-maximal inhibitory concentration: > 10000 nM
Compound 3 ended at the assay's limit; the forecaster's own chance of this, stated with the estimate: 5%; middle value at least 140-fold (2.15 log units) away from the limit.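

In this assay, removing the single oxygen that links the trifluoromethyl group to the aromatic ring, with the rest of the molecule unchanged, gives an at least 250-fold higher number from compound 2 to compound 3 (2.39 log units; beyond the scatter). This step rests on a limit of the assay, yet it shows that trifluoromethoxy and trifluoromethyl are not interchangeable on this aromatic carbon, para to a large group. The earlier step could be read as crediting the fluorine atoms alone, but compound 3 keeps them and compound 1 keeps the oxygen, leaving compound 2, which has both as trifluoromethoxy, as the only compound with a measured number: the limit of > 10000 nM in this assay, at which 2 of the 3 values shown sit.

On these data alone, the step between compound 1 and compound 3 cannot be read, as both values are limits, so how those two compare remains unknown. Also open, as far as these compounds go, is how much of the oxygen-linked fluorinated group is needed, which a difluoromethoxy or ethoxy group at this position could test, along with whether a different group such as an amine would give a measurable number.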